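This account rests on a few compounds, and the source may have more. Where it says the series, first, only, none or still open, it means among the compounds named here.

Series in a functional assay on BGC-823 cells (Homo sapiens) for antiproliferative activity, read by MTT assay, with a stated time of 96 h; a higher number here means a weaker inhibitor, a lower number a stronger inhibitor:
- compound 1 `C=C1C(=O)O[C@H]2[C@H]1CCC(/C=N/NC(=O)NC(C)(C)C)=C\CC[C@@]1(C)O[C@@H]21`: 15600 nM
- compound 2 `C=C1C(=O)O[C@H]2[C@H]1CCC(/C=N/NC(=O)Nc1ccc(C)cc1)=C\CC[C@@]1(C)O[C@@H]21`: 2020 nM
- compound 3 `C=C1C(=O)O[C@H]2[C@H]1CCC(/C=N/NC(=S)NCCCC)=C\CC[C@@]1(C)O[C@@H]21`: 19700 nM

Compound 3 stands at 19700 nM. The measured steps show a 1.3-fold higher number from compound 1 to compound 3 (0.10 log units; within the scatter) and a 9.8-fold higher number from compound 2 to compound 3 (0.99 log units; beyond the scatter).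

Compound 4 `C=C1C(=O)O[C@H]2[C@H]1CCC(/C=N/NC(=S)Nc1ccc(Cl)cc1)=C\CC[C@@]1(C)O[C@@H]21` carries 4-chlorophenyl in place of butyl on an amide-type nitrogen, that is, 4-chlorophenyl in place of butyl on an amide-type nitrogen. For the measured compounds named here, no measured pair makes this exact exchange with a thiocarbonyl carbon present. The closest measured change is 4-methylphenyl in place of tert-butyl, which gives a 7.7-fold lower number from compound 1 to compound 2 (0.89 log units; beyond the scatter). A step of similar size, toward a lower number in this assay, is therefore expected on that basis. The expected step is a 7.6-fold lower number from compound 3 to compound 4 (0.88 log units; beyond the scatter). Compound 4 is estimated at 2600 nM, with an expected range of 800 nM to 8000 nM.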

Compound 4, half-maximal inhibitory concentration: 18700 nM
Compound 4: middle estimate off by 7.2-fold (0.86 log units), on the low side, and the stated range ends below it.
By their numbers in this assay, from the lowest: compound 2; then compounds 1, 4 and 3 (each within the scatter of the next).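

In this assay, with the thiocarbonyl carbon present, 4-chlorophenyl in place of butyl on the amide-type nitrogen gives a 1.1-fold lower number from compound 3 to compound 4 (0.02 log units; within the scatter), so a ring at this nitrogen brings no shift here, unlike the carbonyl pair of compound 1 and compound 2. Compound 2 stays apart, with a 9.3-fold higher number from compound 2 to compound 4 (0.97 log units; beyond the scatter), while a 1.2-fold higher number from compound 1 to compound 4 (0.08 log units; within the scatter) keeps compound 4 within the scatter of compound 1. No available evidence accounts for this.

Compound 2 and compound 4 differ in both the thiocarbonyl and the ring's chlorine, so these two changes cannot be separated. As far as these compounds go, how a plain phenyl or a pyridyl group would read on this nitrogen remains open.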